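A Methyl for a Chloro on the Aryl Ring

The source may hold more compounds than are shown below. What is called first, only, known or untested is meant among the compounds shown, and "the series" means these compounds.

Three compounds were measured in an assay on HEK293 cells for displacement of a labelled ligand from corticotropin-releasing factor receptor 1 (Homo sapiens); on this read-out higher numbers stand for weaker inhibition and lower numbers for stronger inhibition:

compound 1 `CCCN(C)c1cc(C)nc2c(-c3ccc(Cl)cc3Cl)nn(C)c12`, 24 nM
compound 2 `Cc1cc(N(CC(C)C)CC2CC2)c2c(n1)c(-c1ccc(Cl)cc1Cl)nn2C`, 3.7 nM
compound 3 `CCCCN(CCCC)c1cc(C)nc2c(-c3ccc(Cl)cc3Cl)nn(C)c12`, 0.62 nM

Compound 3 gives the lowest number of the three. The steps that reach it are a 39-fold lower number from compound 1 to compound 3 (1.59 log units; beyond the scatter) and a 6.0-fold lower number from compound 2 to compound 3 (0.78 log units; beyond the scatter); the remaining step, a 6.5-fold lower number from compound 1 to compound 2 (0.81 log units; beyond the scatter), lies between the other two. All three steps alter only the amino group on the shared core, while the dichlorophenyl ring is kept unchanged throughout.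

Compound 4 `CCCCN(CCCC)c1cc(C)nc2c(-c3ccc(C)cc3Cl)nn(C)c12` differs from compound 3 by methyl in place of chloro on an aromatic carbon. Going by the values given here, none of the measured steps touches this ring, so no step bears directly on the change, and the data give no basis for expecting a shift beyond the scatter in this assay. On that basis compound 4 is expected to stay close to compound 3, with an estimated value of 0.9 nM, a range of 0.3 nM to 3 nM, and an expected step of a 1.5-fold higher number from compound 3 to compound 4 (0.16 log units; within the scatter).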

Compound 4, inhibition constant: 2.8 nM
For compound 4 the middle estimate is 3.1-fold (0.49 log units) below the measured one, and the stated range covers the measured number.
By their numbers in this assay, from the lowest: compound 3; then compounds 4 and 2 (each within the scatter of the next); then compound 1.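

Going by these compounds alone, the aryl ring, which none of the earlier steps touched, proves able to move the number in this assay: methyl in place of chloro, para to a large group and meta to a chloro group, gives a 4.5-fold higher number from compound 3 to compound 4 (0.65 log units; beyond the scatter). This change exchanges one heavy atom for one heavy atom, with no hydrogen-bond donor or acceptor on either side, yet the step lies beyond the scatter, so the amino group is not the only part of these compounds that matters for this read-out. Nothing among the data shown accounts for this step.

The compounds shown leave open whether fluoro, methoxy or trifluoromethyl at this carbon would match the chloro of compound 3. They also leave open whether the same exchange gives a step of similar size with methyl(propyl)amino, the amino group of compound 1, in place of dibutylamino.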